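Replacing 3-fluorobenzyl with 4-(trifluoromethyl)benzyl

A few compounds are considered here, and "the series" means these few. Any claim that something is new, unique, unknown or untested is made for them only; others in the source may bear on it.

In a functional assay on HCT-116 cells (Homo sapiens) for antiproliferative activity, read by MTT assay, with a stated time of 24 h (a lower number here means a stronger inhibitor, a higher number a weaker inhibitor), compound 1 `COc1cc(OC)c(-c2coc3cc(OCc4ccc(Br)cc4)ccc3c2=O)cc1OC` gives 1980 nM, while compound 2 `COc1cc(OC)c(-c2coc3cc(OCc4cccc(F)c4)ccc3c2=O)cc1OC` gives 4920 nM, the higher of the two numbers. Unmeasured compound 3 `COc1cc(OC)c(-c2coc3cc(OCc4ccc(C(F)(F)F)cc4)ccc3c2=O)cc1OC` has 4-(trifluoromethyl)phenyl in place of 3-fluorophenyl on a saturated chain carbon bound to an oxygen on an aromatic ring. Going by the values given here, one measured step bears on this, the change from 4-bromophenyl to 3-fluorophenyl, a 2.5-fold higher number from compound 1 to compound 2 (0.40 log units; beyond the scatter). A modest move to a lower number is therefore expected in this assay, though one measured step is thin support. The expected step is a 1.8-fold lower number from compound 2 to compound 3 (0.26 log units; within the scatter). The estimate for compound 3 is 2700 nM, within a range of 1100 nM to 6500 nM.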

Compound 3, half-maximal inhibitory concentration: 2440 nM
For compound 3 the middle estimate is 1.1-fold (0.04 log units) above the measured one; the measured number falls inside the stated range.
By their numbers in this assay, from the lowest: compounds 1, 3 and 2 (each within the scatter of the next, the first and the last beyond it).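

In this assay, trifluoromethyl in place of bromo on an aromatic carbon stays within the scatter (a 1.2-fold higher number from compound 1 to compound 3 (0.09 log units; within the scatter)), so these two groups are not told apart at this position. The change from 3-fluorobenzyl to 4-(trifluoromethyl)benzyl also stays within it (a 2.0-fold lower number from compound 2 to compound 3 (0.30 log units; within the scatter)), leaving the step between compound 1 and compound 2 as the only one beyond the scatter. No evidence on the reason for these numbers is at hand. Open, on these data alone, is whether an amine or a carboxylic acid in place of trifluoromethyl would give a step beyond the scatter.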